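The source may hold more compounds than are shown below. What is called first, only, known or untested is meant among the compounds shown, and "the series" means these compounds.

The measured compounds are compound 1 `Cn1c(-c2ccc([N+](=O)[O-])cc2)nc2cc(C(F)(F)F)ccc21`, compound 2 `Cn1c(-c2ccc(N)cc2)nc2cc(C(F)(F)F)ccc21` and compound 3 `COc1ccc(-c2nc3cc(Cl)c(Cl)cc3[nH]2)c([N+](=O)[O-])c1`. In an ADME assay on MT4 cells (Homo sapiens) for cytotoxicity, read by MTT assay, with a stated time of 96 h (on this read-out lower numbers stand for higher toxicity in this test and higher numbers for lower toxicity in this test), compound 1 gives >= 100000 nM, which is a limit of the assay rather than a number. Compound 2 gives 20000 nM in this assay. Compound 3 gives 2000 nM in this assay, the lowest of the two numbers.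

Compound 2 arises from compound 1 by amino in place of nitro on an aromatic carbon, and that change brought an at least 5.0-fold lower number from compound 1 to compound 2 (0.69 log units; beyond the scatter); the starting point of this step is one of the values sitting at the limit of >= 100000 nM in this assay, at which 1 of the 3 values shown sits. Compound 4 `COc1ccc(-c2nc3cc(Cl)c(Cl)cc3[nH]2)c(N)c1`, not yet measured, arises from compound 3 by the same kind of change, (amino in place of nitro on an aromatic carbon), though the place now reads ortho to a large group and meta to a methoxy group rather than para to a large group. The difference between the two cores is not broken down here.

From the compounds shown here alone, because the earlier at least 5.0-fold lower number from compound 1 to compound 2 (0.69 log units; beyond the scatter) starts from a limit, its full size is unknown, and the expectation for the new step is kept smaller. Compound 4 is thus expected to give 800 nM, between 200 nM and 4000 nM, an estimated step of a 2.5-fold lower number from compound 3 to compound 4 (0.40 log units; beyond the scatter).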

Compound 4, half-maximal cytotoxic concentration: 3000 nM
Compound 4: middle estimate off by 3.8-fold (0.57 log units), on the low side; measured number inside the range.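

In this assay, amino in place of nitro on an aromatic carbon gives a 1.5-fold higher number from compound 3 to compound 4 (0.18 log units; within the scatter), so on the core of compound 3 the two values cannot be told apart. The change therefore does not carry over in size from the core of compound 1 to the core of compound 3: the same change on two cores in this assay, an at least 5.0-fold lower number (0.69 log units; beyond the scatter) from compound 1 to compound 2 and a 1.5-fold higher number (0.18 log units; within the scatter) from compound 3 to compound 4, at least 7.5-fold (0.87 log units) apart, beyond the scatter of two such steps

Compound 1 sits at a limit of the assay, which leaves the full size of the earlier step and of the gap unknown, and two pairs cannot show whether the cores or the place of the change account for that gap: the limit of >= 100000 nM in this assay, at which 1 of the 4 values shown sits.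

The compounds shown leave open how a methyl, a hydroxyl or an acetamide in the same place would read in this assay on the core of compound 3. They also leave open whether the amino group would give a step of the earlier kind on the core of compound 1 if it stood ortho to a large group.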